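The compounds below may be only part of what the source reports. "The series", "measured", "known", "first", "only" and "open" are said of these compounds alone.

The compounds share one core, varied at a single side group. Compound 1 `COc1ccc2c(c1)CC/C(=C\c1ccccc1C)C2=O` has been tested in an assay on mitochondria for inhibition of 1,25-dihydroxyvitamin D(3) 24-hydroxylase, mitochondrial (Rattus norvegicus) (on this read-out higher numbers stand for weaker inhibition and lower numbers for stronger inhibition), and stands only at a limit: compound 1 gives > 20000 nM, a limit of the assay and not a number. Compound 2 `COc1ccc2c(c1)CC/C(=C\c1cccc(N(C)C)c1)C2=O` likewise stands at a limit, and in this assay compound 2 gives > 100000 nM. Among the compounds with values here, compound 3 `COc1ccc2c(c1)CCC(Cc1cc(C(F)(F)F)ccc1C(F)(F)F)C2=O` is the one measured compound that gives a number, and in this assay compound 3 gives 4500 nM. Within the data shown here, no two measured compounds differ in only one place, so no single measured step exists here to lean on. Compound 4 `COc1ccc2c(c1)CC/C(=C\c1ccc(O)cc1)C2=O` has not yet been measured; it differs from compound 1 by 4-hydroxyphenyl in place of 2-methylphenyl on a double-bonded chain carbon bound to a double-bonded ring carbon. Since the starting point is a limit, the step is expected to be modest, a step that the limit leaves unreadable from compound 1 to compound 4, not clearly beyond the usual scatter in either direction. Compound 4 is expected to give about 30000 nM in this assay, somewhere between 5000 nM and 200000 nM, quite possibly once more only as a limit.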

Compound 4, half-maximal inhibitory concentration: > 20000 nM
Compound 4: only a limit was reported (the forecaster's own chance of this, stated with the estimate: 60%); the middle value lies beyond the limit too.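

In this assay, compound 1 and compound 4 both stand only at a limit, so no step between them can be read: the limit of > 20000 nM in this assay, at which 2 of the 4 values shown sit.

As far as these compounds go, whether 4-hydroxyphenyl in place of 2-methylphenyl changes inhibition at all stays open, as does the true strength of either compound.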